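A Tetrazole Ring in Place of a Benzyl Group

The source may report more compounds than this note shows. Statements on the series, on what has been measured and on what is new or still open speak of the compounds shown alone.

Of the compounds shown here, three built on one shared core have been tested in a functional assay on REH cells (Homo sapiens) for cytotoxicity, read by MTT assay, with a stated time of 72 h; on this read-out higher numbers stand for weaker inhibition and lower numbers for stronger inhibition. Compound 1 `O=C(CN1C(=O)/C(=C/c2ccc(-c3ccc(Cl)cc3)o2)SC1=S)NCc1ccc(C(F)(F)F)cc1` gives 170000 nM, compound 2 `O=C(CN1C(=O)/C(=C/c2ccc(-c3ccc(Cl)cc3)o2)SC1=S)NCc1ccc(F)cc1` gives 165000 nM, and compound 3 `O=C(CN1C(=O)/C(=C/c2ccc(-c3ccc(Cl)cc3)o2)SC1=S)NCc1ccccc1Cl` gives 70000 nM. Compound 3 therefore holds the lowest number of the three: the step of a 2.4-fold lower number from compound 1 to compound 3 (0.39 log units; beyond the scatter) and the step of a 2.4-fold lower number from compound 2 to compound 3 (0.37 log units; beyond the scatter) point the same way, while a 1.0-fold lower number from compound 1 to compound 2 (0.01 log units; within the scatter) shows no real change. Compound 4 `O=C(CN1C(=O)/C(=C/c2ccc(-c3ccc(Cl)cc3)o2)SC1=S)Nc1nnn[nH]1` carries the change (1H-tetrazol-5-yl in place of 2-chlorobenzyl on an amide-type nitrogen). Within the data shown here, none of the measured steps bears on this change: each of them swaps one benzyl-type group for another, whereas here the whole benzyl group gives way to a five-membered aromatic ring on the amide-type nitrogen. Among the measured compounds shown here, with no comparable step to lean on, the expectation for compound 4 in this assay is a number near that of compound 3, with wide uncertainty in both directions, so the estimated step of a 1.7-fold higher number from compound 3 to compound 4 (0.23 log units; within the scatter) is small. Compound 4 is thus estimated at 120000 nM, within 40000 nM to 400000 nM.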

Compound 4, half-maximal inhibitory concentration: 50000 nM
Compound 4: the middle estimate sits 2.4-fold (0.38 log units) above what was measured, and the stated range covers the measured number.
By their numbers in this assay, from the lowest: compounds 4 and 3 (each within the scatter of the next); then compounds 2 and 1 (each within the scatter of the next).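

A benzyl-type group is not required on the amide-type nitrogen for a measurable number in this assay, since 1H-tetrazol-5-yl in place of 2-chlorobenzyl leaves the number within the scatter (a 1.4-fold lower number from compound 3 to compound 4 (0.15 log units; within the scatter)). Against the two other benzyl-type compounds the same kind of swap gives steps beyond the scatter (a 3.3-fold lower number from compound 2 to compound 4 (0.52 log units; beyond the scatter)) and (a 3.4-fold lower number from compound 1 to compound 4 (0.53 log units; beyond the scatter)), so compound 4 groups with compound 3 and apart from compound 2 and compound 1. Nothing measured here explains why these two very different rings give such similar numbers.

Still open, from the compounds shown here alone, is whether other groups on this nitrogen, such as a plain phenyl ring, a short alkyl chain or a carboxylic acid, would stay in the same range. One swap also cannot separate the role of the four ring nitrogens from that of the smaller ring.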